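Same Atoms, Joined Differently: From Compound 3 to Compound 4

A few compounds are considered here, and "the series" means these few. Any claim that something is new, unique, unknown or untested is made for them only; others in the source may bear on it.

In an ADME assay on microsomes from liver (Homo sapiens) for metabolic stability, read by LC-MS, with a stated time of 30 min, tested at 1 uM (a higher number here means that more of the compound is left, a lower number that less of the compound is left), compound 3 `O=C(NCc1ccc(S(=O)(=O)c2ccccc2)cc1)c1c[nH]c2ccncc12` gives > 99%, which is a limit of the assay and not a number. Compound 3 therefore stands at the limit of > 99% in this assay, at which 1 of the 3 values shown sits.

Compound 4 `O=C(NCc1ccc(S(=O)(=O)c2ccccc2)cc1)c1cc2cnccc2[nH]1` has the same atoms as compound 3, joined differently. The structural change is a group of 9 heavy atoms (7 carbon, 2 nitrogen; one five-membered aromatic ring with 1 hetero atom, one six-membered aromatic ring with 1 hetero atom) in place of a group of 9 heavy atoms (7 carbon, 2 nitrogen; one five-membered aromatic ring with 1 hetero atom, one six-membered aromatic ring with 1 hetero atom), on a carbonyl carbon, and it lies on a carbonyl carbon whose other neighbour is an amide-type nitrogen.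

Compound 3 differs at this same place from compound 2 `O=C(NCc1ccc(S(=O)(=O)c2ccccc2)cc1)c1cn2ccnc2cn1`. In this assay compound 2 gives 87%. Among the measured compounds shown here, the one measured step that bears on the change is a number at least 12 percentage points higher from compound 2 to compound 3 (beyond the scatter), so a replacement at this place has already moved the read-out beyond the scatter. Compound 1 `O=C(NCc1ccc(S(=O)(=O)c2cccc(F)c2)cc1)c1cc2cnccc2[nH]1` carries the group that enters in compound 4 and differs from compound 4 by one added fluorine. For the measured compounds named here, no measured step isolates the present change, so the closest guide is compound 1 at 79%. On that basis, a modest fall in the amount of compound left is expected, and the estimated step is a number at least 14 percentage points lower from compound 3 to compound 4 (beyond the scatter). For compound 4 the expected value is 85%, with an estimated range from 70% to 97%.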

Compound 4, percent of the compound remaining: 75%
For compound 4 the middle estimate is 10 percentage points above the measured one; measured number inside the range.
By their numbers in this assay, from the lowest: compounds 4, 1 and 2 (each within the scatter of the next, the first and the last beyond it). At a limit, above all of these: compound 3.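

In this assay, the read-out at this carbonyl carbon depends on how the atoms of the group are joined and not only on which atoms it holds: with the same atoms in a different arrangement, the result is a number at least 24 percentage points lower from compound 3 to compound 4 (beyond the scatter). The figure for compound 3 is a limit and not a number: the limit of > 99% in this assay, at which 1 of the 4 values shown sits.

Among the compounds shown here, the group entering in compound 4 also compares with the group of compound 2, giving a number 12 percentage points lower from compound 2 to compound 4 (beyond the scatter), while the single change of hydrogen in place of fluoro on an aromatic carbon gives a number 4 percentage points lower from compound 1 to compound 4 (within the scatter), which leaves the lower read-out of compound 1 in line with the group it shares with compound 4.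

The compounds shown do not settle whether fluoro on the phenyl sulfone of compound 3 would leave its read-out unchanged, as the same change does between compound 1 and compound 4. They also leave open how a methyl group or an amine on the shared core would affect the amount of compound left, and what in the joining of the atoms accounts for the difference.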